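A few compounds are considered here, and "the series" means these few. Any claim that something is new, unique, unknown or untested is made for them only; others in the source may bear on it.

Compound 1 `CCCOc1ccc(C(=O)NNc2c(Br)cccc2Br)cc1` is the parent of this step. In a toxicity assay on MDCK cells (Canis lupus familiaris) for cytotoxicity, read by CCK-8 assay, with a stated time of 48 h (on this read-out higher numbers stand for lower toxicity in this test and lower numbers for higher toxicity in this test), compound 1 gives > 100000 nM, which is a limit of the assay and not a number. The neighbouring pair rests on the same footing. Compound 2 `CCOc1ccc(C(=O)NNc2c(C)cccc2C)cc1` gives > 100000 nM in this assay, again a limit. Compound 3 `Cc1cccc(C)c1NNC(=O)c1ccc(C(C)(C)C)cc1` gives > 100000 nM in this assay, also a limit. For the measured compounds named here, the one measured step, a step that the two limits leave unreadable from compound 2 to compound 3, is unreadable in size because of the limit of > 100000 nM in this assay, at which 3 of the 3 values shown sit. Compound 4 `Nc1ccc(C(=O)NNc2c(Br)cccc2Br)cc1` differs from compound 1 by amino in place of propoxy on an aromatic carbon. No measured step touches either the propoxy group or an amino group, so none bears directly on this change, and the single step shown has no readable size. With every value sitting at the limit, no direction beyond the scatter can be read for this assay from the compounds shown. Compound 4 is expected to give about 150000 nM in this assay, within a range of 60000 nM to 400000 nM. The step that the limit leaves unreadable from compound 1 to compound 4 is expected to be none beyond the scatter, most likely reported again only as a limit.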

Compound 4, half-maximal cytotoxic concentration: > 100000 nM
Compound 4: a limit, no number (the forecaster's own chance of this, stated with the estimate: 80%); the middle value lies beyond the limit too.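

No size can be read for the step between compound 1 and compound 4 in this assay because both compounds give a limit of the assay and not a number: the limit of > 100000 nM in this assay, at which 4 of the 4 values shown sit. The compounds shown leave open how amino and propoxy compare on this read-out, and whether any compound in the series has a measurable half-maximal cytotoxic concentration.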